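Thioester series: methyl replacing phenyl on the carbonyl carbon

This account rests on a few compounds, and the source may have more. Where it says the series, first, only, none or still open, it means among the compounds named here.

Compound 1 `CCOC(=O)[C@@H](N)CCC(=O)NCCSC(=O)c1ccccc1` and compound 2 `CCCCOC(=O)[C@@H](N)CCC(=O)NCCSC(=O)c1ccccc1` share one core and have both been run in an ADME assay on liver for metabolic stability, with liver carboxylesterase 1 (Homo sapiens) as the target; on this read-out lower numbers stand for a shorter-lived compound and higher numbers for a longer-lived compound. Compound 1 gives 0.167 h, and compound 2 gives 0.167 h; the step of no change at the digits printed from compound 1 to compound 2 (within the scatter) is the only one measured so far, and it concerns the ester side of the core, not the thioester. Compound 1 thus stands level with compound 2 on the numbers in hand.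

Compound 3 `CCOC(=O)[C@@H](N)CCC(=O)NCCSC(C)=O` has not yet been measured. It differs from compound 1 by methyl in place of phenyl on a carbonyl carbon. Among the compounds with values here, no measured step touches this carbonyl carbon, so the single step from compound 1 to compound 2 bears on it only in showing that the core as a whole sits at one value. On that basis the step of a 1.0-fold higher number from compound 1 to compound 3 (0.01 log units; within the scatter) is expected to stay within the scatter, with no direction beyond it. For compound 3 the estimate in this assay is 0.17 h, with a range from 0.08 h to 0.4 h.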

Compound 3, half-life in the liver carboxylesterase 1 assay: 0.167 h
Compound 3: the middle estimate sits 1.0-fold (0.01 log units) above what was measured, within the range that was stated.
By their numbers in the liver carboxylesterase 1 assay, from the lowest: compounds 1, 2 and 3 (each within the scatter of the next).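

In the liver carboxylesterase 1 assay compound 1 gives 0.167 h and compound 3 gives 0.167 h. In the liver carboxylesterase 1 assay, methyl in place of phenyl on a carbonyl carbon whose other neighbours are sulfur gives no change at the digits printed from compound 1 to compound 3 (within the scatter), so this position, which the earlier step on the ester side did not touch, also shows no separation, even with the six-membered aromatic ring gone. In a physicochemical assay for acid dissociation, using potentiometric titration, at pH 2, compound 1 gives 8.85 and compound 3 gives 8.94. In the physicochemical assay the same change gives a number 0.09 log units higher from compound 1 to compound 3 (within the scatter), so neither read-out separates methyl from phenyl here. No supporting information on hand bears on these results.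

Going by these compounds, with compounds 1, 2 and 3 all level, it remains open whether the liver carboxylesterase 1 assay can separate members at all. A longer chain or an amine in place of methyl on this carbonyl carbon, or a carboxylic acid in place of the ester, remains the open test of whether the number can move.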